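Swapping the Benzyl Fluorine for a Sulfamoyl Amine

The compounds below may be only part of what the source reports. "The series", "measured", "known", "first", "only" and "open" are said of these compounds alone.

Compound 1 `COCCOc1no[n+]([O-])c1S(=O)(=O)c1ccccc1`: 4780 nM
Compound 2 `Cc1c(Cc2ccc(F)cc2)c(=O)oc2cc(OCCOc3no[n+]([O-])c3S(=O)(=O)c3ccccc3)ccc12`: 3.7 nM

Both were tested in a functional assay on A549 cells (Homo sapiens) for antiproliferative activity, read by MTT assay, with a stated time of 48 h; a lower number here means a stronger inhibitor, a higher number a weaker inhibitor. Compound 2 gives the lowest number of the two, and the gap to compound 1 is far beyond the usual scatter, so compound 2 is clearly the stronger inhibitor in this set.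

Compound 3 `CNS(=O)(=O)Nc1cccc(Cc2c(C)c3ccc(OCCOc4no[n+]([O-])c4S(=O)(=O)c4ccccc4)cc3oc2=O)c1` keeps the whole of compound 2 except for one ring: 3-((methylsulfamoyl)amino)phenyl in place of 4-fluorophenyl on a saturated chain carbon bound to an aromatic carbon. Among the measured compounds shown here, no pair of measured compounds shares this kind of change, so the size of the step can only be guessed. Because compound 2 sits at 3.7 nM and the rest of the molecule is unchanged, compound 3 is expected to stay close to it, with at most a modest rise in the number: the expected step of a 2.2-fold higher number from compound 2 to compound 3 (0.33 log units; beyond the scatter) is a small loss, near the edge of the scatter. Compound 3 is estimated at 8 nM, within a range from 2 nM to 40 nM.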

Compound 3, half-maximal inhibitory concentration: 7.9 nM
Estimate against measurement, compound 3: 1.0-fold (0.01 log units) above; measured number inside the range.
By their numbers in this assay, from the lowest: compound 2; then compound 3; then compound 1.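

In this assay, the place on a saturated chain carbon bound to an aromatic carbon accepts a larger ring group at modest cost: 3-((methylsulfamoyl)amino)phenyl, with 12 heavy atoms and 2 hydrogen-bond donors, replaces 4-fluorophenyl, with 7 heavy atoms and no donors, giving a 2.1-fold higher number from compound 2 to compound 3 (0.33 log units; beyond the scatter). This small loss lies beyond the usual scatter, so it counts as real, yet the position clearly does not demand a small fluorinated ring. Nothing shown here accounts for the size of the step.

The swap changes both the group on the phenyl ring and its numbered place there, so these two effects cannot be told apart. A plain phenyl, a 3-fluorophenyl or a 3-aminophenyl ring would help to separate them.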